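Chloro Substituent on the Anilino Ring of Compound 1

The source may hold more compounds than are shown below. What is called first, only, known or untested is meant among the compounds shown, and "the series" means these compounds.

Measured compounds:
compound 1, `Nc1ccccc1NC(=O)c1ccc(Cn2cnc3c(Nc4ccccc4)nc(Cl)nc32)cc1`, 83.5%
compound 2, `Cc1ccc(Nc2nc(Cl)nc3c2ncn3Cc2ccc(/C=C/C(=O)Nc3ccccc3N)cc2)cc1`, 15%
compound 3, `CC(C)n1cnc2c(NCc3ccc(C(=O)Nc4ccccc4N)cc3)nc(Cl)nc21`, 76%

In a functional assay on HCT-116 cells (Homo sapiens) for antiproliferative activity, read by CCK-8 assay, with a stated time of 72 h, tested at 8 uM (a higher number here means a stronger effect of the compound at the concentration tested, a lower number a weaker effect), compound 1 gives the highest of the three numbers. Compound 3 lies close to it, within the usual scatter, so no order between these two can be read from the data. Compound 2 sits far lower, beyond the scatter.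

Compound 4, `Nc1ccccc1NC(=O)c1ccc(Cn2cnc3c(Nc4cccc(Cl)c4)nc(Cl)nc32)cc1`, has not yet been measured. It differs from compound 1 in one place: chloro in place of hydrogen on an aromatic carbon. Going by the values given here, no measured pair shows this same change, so nothing in the data sets its size. The expectation is a step of a number 3.5 percentage points lower from compound 1 to compound 4 (within the scatter) of no size beyond the scatter. Compound 4 is therefore estimated at 80%, with a range from 62% to 92%.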

Compound 4, a percentage reported as inhibition, at one concentration (the size of the read-out at that concentration, not a potency): 78.4%
Estimate against measurement, compound 4: 1.6 percentage points above, and the stated range covers the measured number.
By their numbers in this assay, from the lowest: compound 2; then compounds 3, 4 and 1 (each within the scatter of the next).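

In this assay, placing a chloro group on the anilino ring of compound 1 gives a number 5.1 percentage points lower from compound 1 to compound 4 (within the scatter). Going by these compounds alone, this is the first reading of any change on that ring, and it shows that 3-chlorophenyl can replace phenyl here without a difference that can be told apart from the scatter at this one concentration. Nothing measured here explains this result.

As far as these compounds go, whether a methoxy group, an amine or a carboxylic acid at the same place would read the same remains open. So does whether chloro elsewhere on this ring would behave like this one.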